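Methyl added ortho to the sulfonamide in compound 2

The compounds below may be only part of what the source reports. "The series", "measured", "known", "first", "only" and "open" are said of these compounds alone.

Measured so far in a functional assay on CHO cells for agonist activity at Alpha-1A adrenergic receptor (Homo sapiens), read by FLIPR and calcium flux; on this read-out higher numbers stand for larger maximal responses and lower numbers for smaller maximal responses:
Compound 1 `COc1c(C)ccc2c1CCC2c1ncc[nH]1`: 40%
Compound 2 `CS(=O)(=O)Nc1cccc2c1CCC2c1ncc[nH]1`: 87%
Compound 3 `Cn1cc(-c2cccc3c2CCC3c2ncc[nH]2)cn1`: 12%

Compound 2 gives the highest of the three numbers; its nearest neighbour is compound 1, and compound 3 lies furthest below it, both gaps beyond the scatter. For the measured compounds named here, the one step with a single change, a number 75 percentage points lower from compound 2 to compound 3 (beyond the scatter), replaces the methanesulfonamido group itself and erases most of the response.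

Compound 4 `Cc1ccc2c(c1NS(C)(=O)=O)CCC2c1ncc[nH]1` keeps that group and differs from compound 2 only by methyl in place of hydrogen on an aromatic carbon.

Going by the values given here, no measured step adds a methyl group to this core while keeping the methanesulfonamido group; compound 1 carries a methyl but differs from compound 2 in more than one place, so it gives no single step. The step that bears on the position shows the response depends on the methanesulfonamido group, which compound 4 retains. The expectation is therefore a step of a number 7 percentage points lower from compound 2 to compound 4 (within the scatter) within or near the scatter, with no direction firmly indicated. Compound 4 is estimated at 80%, in the range 55% to 100%.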

Compound 4, largest response reached (Emax), in percent of the reference or control that the assay uses: 83%
Compound 4: middle estimate off by 3 percentage points, on the low side; measured number inside the range.
By their numbers in this assay, from the lowest: compound 3; then compound 1; then compounds 4 and 2 (each within the scatter of the next).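

In this assay, methyl in place of hydrogen on the aromatic carbon ortho to the methanesulfonamido group leaves the response within the scatter, with a number 4 percentage points lower from compound 2 to compound 4 (within the scatter). This position therefore accepts a methyl without loss of the response seen with hydrogen. Compound 4 also gives compound 1 its first single-place comparison, a number 43 percentage points higher from compound 1 to compound 4 (beyond the scatter), so with the methyl present, methanesulfonamido and methoxy are clearly separated, in line with the loss at the pyrazolyl replacement in the hydrogen series. No measurement on hand accounts for either step.

The compounds shown leave open whether this carbon accepts anything larger than methyl, such as an ethyl group or a longer chain. They also leave open whether an acetamido group could stand in for the methanesulfonamido group.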